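Amidine series: methylation of the ring nitrogen

The compounds below may be only part of what the source reports. "The series", "measured", "known", "first", "only" and "open" are said of these compounds alone.

Measured compounds:
compound 1 `Cn1nc(-c2ccccc2)c2cc(C(=N)Nc3ccccc3)ncc21` — 11100 nM
compound 2 `CN1CCN(c2ccc(NC(=N)c3cc4cnn(C)c4cn3)cc2)CC1` — 30200 nM
compound 3 `CN1CCN(c2ccc(NC(=N)c3cc4c(-c5ccccc5)n[nH]c4cn3)cc2)CC1` — 15900 nM

In a functional assay on MDA-MB-231 cells (Homo sapiens) for cytotoxicity, read by MTT assay, with a stated time of 72 h (a higher number here means a weaker inhibitor, a lower number a stronger inhibitor), compound 1 gives 11100 nM, compound 2 gives 30200 nM, and compound 3 gives 15900 nM. Going by the values given here, all three numbers lie within the scatter of one another, so no compound separates from the others, and compound 3 cannot be ranked against compound 1 or compound 2 on this assay; the values simply sit in one band.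

Compound 4 `CN1CCN(c2ccc(NC(=N)c3cc4c(-c5ccccc5)nn(C)c4cn3)cc2)CC1` differs from compound 3 by one change: methyl in place of hydrogen on an aromatic nitrogen. Among the compounds with values here, no measured pair shows this change on its own, and the two compounds already carrying that methyl, compound 1 and compound 2, lie within scatter of compound 3. Nothing here points in either direction.

Compound 4 is therefore expected to give a number within the same band, and the step of a 1.1-fold lower number from compound 3 to compound 4 (0.03 log units; within the scatter) is expected to be no more than scatter. The estimate for compound 4 is 15000 nM, with a range from 6000 nM to 40000 nM.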

Compound 4, half-maximal inhibitory concentration: 4900 nM
Estimate against measurement, compound 4: 3.1-fold (0.49 log units) above, and the stated range ends above it.
By their numbers in this assay, from the lowest: compound 4; then compounds 1, 3 and 2 (each within the scatter of the next, the first and the last beyond it).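

In this assay, going by these compounds alone, methyl in place of hydrogen on the aromatic nitrogen, two ring bonds from the ring atom that bears a phenyl group, gives a 3.2-fold lower number from compound 3 to compound 4 (0.51 log units; beyond the scatter) and provides the first reading of this change on its own, with a step beyond the scatter. The other two single changes also lie beyond the scatter: phenyl in place of hydrogen gives a 6.2-fold lower number from compound 2 to compound 4 (0.79 log units; beyond the scatter) and 4-methylpiperazin-1-yl in place of hydrogen gives a 2.3-fold lower number from compound 1 to compound 4 (0.36 log units; beyond the scatter) in the same assay. Compound 4 is therefore the strongest of the four, and it alone carries the methyl, the phenyl and the 4-methylpiperazin-1-yl group together. No supporting data explain this step.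

On these data alone, whether the methyl step holds in a compound lacking the phenyl or the 4-methylpiperazin-1-yl group remains open. Also open, as far as these compounds go, is how an ethyl group or a longer chain ending in an amine would read on this nitrogen.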